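A few compounds are considered here, and "the series" means these few. Any claim that something is new, unique, unknown or untested is made for them only; others in the source may bear on it.

Going by the values given here, in an ADME assay on HepG2 cells (Homo sapiens) for cytotoxicity, read by luminescence, CellTiter-Glo and ATP content, with a stated time of 72 h (on this read-out lower numbers stand for an effect already at smaller amounts and higher numbers for an effect only at larger amounts of compound), compound 2 `COc1ccc(F)cc1CNCCCNc1ccnc2cc(-c3ccc(F)cc3)ccc12` gives 770 nM, the lower of the two numbers measured so far. Compound 1 `COc1cccc(Oc2ccc3c(NCCCNCc4cc(F)ccc4OC)ccnc3c2)c1` gives 7100 nM, and the step of a 9.2-fold lower number from compound 1 to compound 2 (0.96 log units; beyond the scatter) goes with the replacement of 3-methoxyphenoxy by 4-fluorophenyl. Compound 3 `COc1ccc(F)cc1CNCCCNc1ccnc2cc(Oc3cccc(N(C)C)c3)ccc12` carries 3-(dimethylamino)phenoxy in place of 4-fluorophenyl on an aromatic carbon, which brings a phenoxy group back to that place. Among the compounds with values here, the step from compound 1 to compound 2 therefore bears on it, run in the opposite direction, so a higher number is expected for compound 3, although no measured step shows the dimethylamino group itself. Compound 3 is expected near 4000 nM, between 1500 nM and 12000 nM, an expected step of a 5.2-fold higher number from compound 2 to compound 3 (0.72 log units; beyond the scatter).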

Compound 3, half-maximal effective concentration: 3300 nM
For compound 3 the middle estimate is 1.2-fold (0.08 log units) above the measured one, within the range that was stated.
By their numbers in this assay, from the lowest: compound 2; then compound 3; then compound 1.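

Compound 3 keeps a phenoxy group at this position, and a 4.3-fold higher number from compound 2 to compound 3 (0.63 log units; beyond the scatter) shows that the number stays higher than with 4-fluorophenyl even with dimethylamino on that ring. The substituent on the phenoxy ring also counts: a 2.2-fold lower number from compound 1 to compound 3 (0.33 log units; beyond the scatter) is a smaller step, though still beyond the scatter. No measurement shown here explains either step.

A plain phenoxy group would help to separate the effect of the oxygen link from that of the ring substituent. Going by these compounds, how a carboxylic acid on the phenoxy ring would behave also remains open.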